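Ortho substituent swaps on the benzylamide core

The source may report more compounds than this note shows. Statements on the series, on what has been measured and on what is new or still open speak of the compounds shown alone.

Measured so far:
compound 1 `CC(C(=O)NCc1ccc(C(C)(C)C)cc1N1CCCCC1)c1ccc(NS(C)(=O)=O)c(F)c1` — 1.9 nM
compound 2 `CC(C(=O)NCc1ccc(C(C)(C)C)cc1OCc1ccccc1)c1ccc(NS(C)(=O)=O)c(F)c1` — 2.9 nM

Among the measured compounds shown here, compound 2 `CC(C(=O)NCc1ccc(C(C)(C)C)cc1OCc1ccccc1)c1ccc(NS(C)(=O)=O)c(F)c1` sits at the higher of the two numbers in an assay on cells for antagonist activity at transient receptor potential cation channel subfamily V member 1 (Homo sapiens), read by FLIPR and calcium flux, with a stated time of 6 min (on this read-out lower numbers stand for stronger inhibition and higher numbers for weaker inhibition), with compound 1 `CC(C(=O)NCc1ccc(C(C)(C)C)cc1N1CCCCC1)c1ccc(NS(C)(=O)=O)c(F)c1` its only neighbour, and the step of a 1.5-fold higher number from compound 1 to compound 2 (0.18 log units; within the scatter) is within the scatter, so the two values cannot be ordered.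

Compound 3 `CCCCCc1cc(C(C)(C)C)ccc1CNC(=O)C(C)c1ccc(NS(C)(=O)=O)c(F)c1` is the next variation on the same position: pentyl in place of benzyloxy on an aromatic carbon. For the measured compounds named here, the only measured step that bears on this position is a 1.5-fold higher number from compound 1 to compound 2 (0.18 log units; within the scatter), where one ortho group replaced another with no change beyond the scatter. Going by the values given here, that single step gives no sign that the group at this position sets the number, but it covers only two groups and says nothing directly about a pentyl chain.

Among the compounds with values here, on that basis the step of a 1.2-fold higher number from compound 2 to compound 3 (0.08 log units; within the scatter) is expected to stay within the scatter, with the range widened because no open-chain group has yet been tried here. Compound 3 is estimated at 3.5 nM in this assay, between 1.2 nM and 12 nM.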

Compound 3, inhibition constant: 2.8 nM
The estimate for compound 3 lay 1.3-fold (0.10 log units) above the measured number; the measured number falls inside the stated range.
By their numbers in this assay, from the lowest: compounds 1, 3 and 2 (each within the scatter of the next).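

In this assay, the open-chain pentyl group sits with benzyloxy and piperidin-1-yl on the same aromatic carbon, ortho to a large group, and both new steps, a 1.0-fold lower number from compound 2 to compound 3 (0.02 log units; within the scatter) and a 1.5-fold higher number from compound 1 to compound 3 (0.17 log units; within the scatter), lie within the scatter, so the three compounds cannot be ordered. The change from compound 2 to compound 3 replaces 8 heavy atoms with 5 and removes both the six-membered aromatic ring and the hydrogen-bond acceptor of benzyloxy, so among these three compounds, neither that ring nor that acceptor is required for a value in this range. No evidence is available to explain why these three groups give values within the scatter of one another.

From the compounds shown here alone, it remains open whether this tolerance extends to a carboxylic acid, a primary amine, a methyl group or a chain longer than pentyl at this position. Going by these compounds, it is also open whether pentyl and benzyloxy would still give values within the scatter of each other if a trifluoromethyl group replaced the tert-butyl group.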